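The compounds below may be only part of what the source reports. "The series", "measured", "known", "first", "only" and "open" are said of these compounds alone.

Working notes on the series. Among the compounds with values here, compound 1 `COc1cccc(/C=C/C(=O)c2sc(Nc3ccccc3)nc2C)c1` and compound 2 `Cc1nc(Nc2cccc(Cl)c2)sc1C(=O)/C=C/c1ccc(Cl)cc1` are the two measured members. In a functional assay on Bel-7402 cells (Homo sapiens) for cytotoxicity, read by MTT assay (on this read-out lower numbers stand for stronger inhibition and higher numbers for weaker inhibition), compound 1 gives > 25000 nM, which is a limit of the assay rather than a number. In this assay compound 2 likewise gives > 25000 nM, again a limit and not a number. Compound 2 therefore stands at the limit of > 25000 nM in this assay, at which 2 of the 2 values shown sit. Within the data shown here, no measured step between the two compounds is available, since they differ in more than one place, and their two values show only that neither reaches a measurable potency in this assay.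

Compound 3 `COc1cccc(/C=C/C(=O)c2sc(Nc3cccc(Cl)c3)nc2C)c1` has not yet been measured. It differs from compound 2 by 3-methoxyphenyl in place of 4-chlorophenyl on a double-bonded chain carbon bound to a double-bonded chain carbon; the same 3-methoxyphenyl group is present in compound 1. With both known compounds sitting at the limit, the expected step that the limit leaves unreadable from compound 2 to compound 3 is none beyond the scatter, and the outcome is most likely another limit rather than a number. Compound 3 is accordingly estimated at 30000 nM in this assay, with an expected range from 10000 nM to 100000 nM.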

Compound 3, half-maximal inhibitory concentration: > 25000 nM
Compound 3: only a limit was reported; the forecaster's own chance of this, stated with the estimate: 80%; the middle value does not contradict the limit.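

In this assay compound 3 gives > 25000 nM, which is a limit and not a number. The steps to compound 3 from compound 1 and from compound 2 therefore cannot be read, and all three compounds share one position: the limit of > 25000 nM in this assay, at which 3 of the 3 values shown sit.

The compounds shown leave open whether any change on the shared core gives a measurable potency in this assay.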